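The source may report more compounds than this note shows. Statements on the series, on what has been measured and on what is new or still open speak of the compounds shown alone.

Measured so far in an ADME assay on HepG2 cells (Homo sapiens) for cytotoxicity, read by CellTiter-Glo and resazurin assay, with a stated time of 72 h; on this read-out higher numbers stand for an effect only at larger amounts of compound and lower numbers for an effect already at smaller amounts:

compound 1, `CCOC(=O)CCCCCOc1cccc(CN(C(=O)c2ccccc2)C(C)C)c1` — compound 1 gives > 26000 nM, a limit of the assay rather than a number.
compound 2, `CCOC(=O)CCCCCOc1cccc(CN(C(=O)c2ccc(-c3ccc(Cl)c(Cl)c3)cc2)C(C)C)c1` — compound 2 gives > 26000 nM, again only a limit.
compound 3, `CCOC(=O)CCCCCOc1cccc(CN(C(=O)c2ccc(Br)cc2)C(C)C)c1` — compound 3 gives > 26000 nM, again only a limit.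

Compound 3 therefore stands at the same limit as every other value in the set, and nothing places it above or below them: the limit of > 26000 nM in this assay, at which 3 of the 3 values shown sit.

The next compound, compound 4 (`CCOC(=O)CCCCCOc1cccc(CNC(C)C)c1`), differs from compound 3 by hydrogen in place of (4-bromophenyl)carbonyl on an amine nitrogen. The measured steps that come closest all change the substituent on the carbonyl-bearing ring while keeping the amide itself: a step that the two limits leave unreadable from compound 1 to compound 3, a step that the two limits leave unreadable from compound 1 to compound 2 and a step that the two limits leave unreadable from compound 2 to compound 3. Each of these is left unreadable by the limits at both ends, so they set no size and no direction. Among the measured compounds shown here, the change to compound 4 goes further than any of them, removing the whole acyl group and leaving a secondary amine, and no measured step covers that.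

With three limits and no readable step, the working expectation for compound 4 is that the step that the limit leaves unreadable from compound 3 to compound 4 is none beyond the scatter. Compound 4 is thus estimated at 30000 nM, with a range from 8000 nM to 100000 nM, and most likely reported again as a limit.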

Compound 4, half-maximal effective concentration: > 26000 nM
Compound 4: only a limit was reported (the forecaster's own chance of this, stated with the estimate: 70%); the middle value is on the limit's open side.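

In this assay compound 4 gives > 26000 nM, a limit and not a number, so no step from compound 1 or compound 3 to compound 4 can be read: the limit of > 26000 nM in this assay, at which 4 of the 4 values shown sit.

On these data alone, whether any of these changes, including hydrogen in place of the acyl group on the amine nitrogen, alters the read-out at all remains open.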